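Swapping Chloro for Nitro on the Aryl Ring of Compound 2

A few compounds are considered here, and "the series" means these few. Any claim that something is new, unique, unknown or untested is made for them only; others in the source may bear on it.

compound 1 `Cc1ccc(C2=Nn3c(nnc3C(C)c3ccc(CC(C)C)cc3)SC2)cc1`: 8500 nM
compound 2 `CC(c1ccc(-c2ccccc2)c(F)c1)c1nnc2n1N=C(c1ccc(Cl)cc1)CS2`: 6100 nM

In a functional assay on Mahlavu cells (Homo sapiens) for inhibition, read by sulforhodamine B assay, with a stated time of 72 h (a lower number here means a stronger inhibitor, a higher number a weaker inhibitor), compound 2 gives 6100 nM, the lowest of the two numbers shown, while compound 1 gives 8500 nM, which lies within the usual scatter of that result. Compound 3 `CC(c1ccc(-c2ccccc2)c(F)c1)c1nnc2n1N=C(c1ccc([N+](=O)[O-])cc1)CS2` is compound 2 with nitro in place of chloro on an aromatic carbon. For the measured compounds named here, no measured pair shows this same change, so nothing here fixes its size; a shift beyond the scatter is not expected in either direction. Compound 3 is therefore estimated at 5000 nM, with a range from 1500 nM to 17000 nM. The expected step is a 1.2-fold lower number from compound 2 to compound 3 (0.09 log units; within the scatter).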

Compound 3, half-maximal inhibitory concentration: 9400 nM
For compound 3 the middle estimate is 1.9-fold (0.27 log units) below the measured one; the measured number falls inside the stated range.
By their numbers in this assay, from the lowest: compounds 2, 1 and 3 (each within the scatter of the next).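

In this assay, putting 4-nitrophenyl where 4-chlorophenyl stood gives a 1.5-fold higher number from compound 2 to compound 3 (0.19 log units; within the scatter). At this position, then, a nitro group with three heavy atoms and two hydrogen-bond acceptors reads the same, within the scatter, as a single chlorine with none. Nothing available explains this similarity. Still open, on these data alone, is whether an amine or a carboxylic acid at this same place would move the number beyond the scatter. It is also unknown whether the chloro-to-nitro swap would read alike with a different group elsewhere on the shared core.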